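Cytotoxicity of a naphthyl analogue of a thiourea urea series

This account rests on a few compounds, and the source may have more. Where it says the series, first, only, none or still open, it means among the compounds named here.

Compound 1 `NC(=S)Nc1cccc(OCCCCCN2CCN(c3ccc(Cl)cc3)C2=O)c1` is the most tolerated of three compounds in an ADME assay on Huh-7 cells (Homo sapiens) for cytotoxicity (a lower number here means that less compound is tolerated, a higher number that more compound is tolerated), where compound 1 gives 39000 nM. Compound 2 `NC(=S)Nc1cccc(OCCCCCN2CCCN(c3ccc(Cl)cc3)C2=O)c1` gives 15000 nM in this assay, and compound 3 `NC(=S)Nc1cccc(OCCCCCN2CCCCN(c3ccc(Cl)cc3)C2=O)c1` gives 13000 nM, both below compound 1 by more than the usual scatter. Compound 4 `NC(=S)Nc1cccc(OCCCCCN2CCN(c3cccc4ccccc34)C2=O)c1` has not yet been measured in this assay. It differs from compound 1 by naphthalen-1-yl in place of 4-chlorophenyl on an amide-type nitrogen in a ring. For the measured compounds named here, no measured pair shows this change, so the expected step from compound 1 to compound 4 in this assay is a 1.6-fold lower number from compound 1 to compound 4 (0.19 log units; within the scatter), probably not beyond the scatter. Compound 4 is estimated to give 25000 nM in this assay, within a range from 8000 nM to 70000 nM.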

Compound 4, half-maximal cytotoxic concentration: 15000 nM
The estimate for compound 4 lay 1.7-fold (0.22 log units) above the measured number; the measured number falls inside the stated range.
By their numbers in this assay, from the lowest: compounds 3, 2 and 4 (each within the scatter of the next); then compound 1.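

For the compounds shown here, the earlier compounds all carry 4-chlorophenyl, so this is the first reading of a change at this position. In this assay the swap to naphthalen-1-yl gives a 2.6-fold lower number from compound 1 to compound 4 (0.41 log units; beyond the scatter) and so lowers the number, showing that the group on this nitrogen matters as well as the ring that bears it. Nothing measured here accounts for this step.

From the compounds shown here alone, whether the second aromatic ring or the loss of chlorine matters more stays open, and a plain phenyl on this nitrogen would help separate them. Also open, going by these compounds, is how naphthalen-1-yl behaves on the larger rings of compound 2 and compound 3.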